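Bromo in place of methylsulfanyl in compound 2

A few compounds are considered here, and "the series" means these few. Any claim that something is new, unique, unknown or untested is made for them only; others in the source may bear on it.

Three compounds have been measured in a functional assay on MOLT-4 cells (Homo sapiens); on this read-out lower numbers stand for stronger inhibition and higher numbers for weaker inhibition:
compound 1 `CSc1nc(SC)c2ncn([C@@H]3C[C@@H](O)[C@H](CO)O3)c2n1` gives 141 uM
compound 2 `CNc1nc(SC)nc2c1ncn2[C@@H]1C[C@@H](O)[C@H](CO)O1` gives > 300 uM, which is a limit of the assay rather than a number
compound 3 `CSc1nc(N(C)C)c2ncn([C@@H]3C[C@@H](O)[C@H](CO)O3)c2n1` gives 172 uM

Compound 2 therefore stands at the top of the shown values in this assay, with only a limit to its name, the one value of the three that sits at that limit (the limit of > 300 uM in this assay, at which 1 of the 3 values shown sits). The measured steps all concern the other substituent on the shared core: an at least 2.1-fold higher number from compound 1 to compound 2 (0.32 log units; beyond the scatter), a 1.2-fold higher number from compound 1 to compound 3 (0.09 log units; within the scatter) and an at least 1.7-fold lower number from compound 2 to compound 3 (0.24 log units; that floor lies within the scatter). None of them touches the methylsulfanyl group that changes now.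

Compound 4 `CNc1nc(Br)nc2c1ncn2[C@@H]1C[C@@H](O)[C@H](CO)O1` differs from compound 2 by bromo in place of methylsulfanyl on an aromatic carbon. Among the compounds with values here, since no measured step bears on this position, the direction and size of the change in this assay cannot be read from the data, and the starting point is only a limit. Compound 4 is therefore expected to remain weak, with an estimated step of a number no higher from compound 2 to compound 4 (the limit leaves the size open). For compound 4 the estimate in this assay is 300 uM, within a wide range from 80 uM to 1000 uM, with a fair chance that again only a limit is reported.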

Compound 4, concentration for 50% inhibition: 177 uM
Compound 4: middle estimate off by 1.7-fold (0.23 log units), on the high side; measured number inside the range.
By their numbers in this assay, from the lowest: compounds 1, 3 and 4 (each within the scatter of the next). At a limit, above all of these: compound 2.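

Within the data shown here, until now every measured step concerned the other substituent on the shared core, and this is the first to touch the aromatic carbon between two ring nitrogen atoms. In this assay, bromo in place of methylsulfanyl at this carbon gives an at least 1.6-fold lower number from compound 2 to compound 4 (0.22 log units; that floor lies within the scatter), and compound 4 reads 177 uM with the methylamino group kept. With that group in place, then, methylsulfanyl is not needed at this carbon for a number to be read rather than a limit, although the step itself shows only a floor and leaves its true size unknown, because the value of compound 2 is a limit and not a number: the limit of > 300 uM in this assay, at which 1 of the 4 values shown sits.

The compounds shown leave open how an amino group, a chloro group or a longer chain such as ethylsulfanyl would read on this same carbon. They also leave open whether bromo in place of methylsulfanyl would give a similar step with the dimethylamino group of compound 3 instead of the methylamino group, where the starting value is a number rather than a limit.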